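The source may hold more compounds than are shown below. What is called first, only, known or untested is meant among the compounds shown, and "the series" means these compounds.

Measured in a functional assay on HL-60 cells (Homo sapiens) for inhibition, read by CCK-8 assay, with a stated time of 48 h, tested at 20 uM; a higher number here means more inhibition of growth at the concentration tested, a lower number less inhibition of growth:
- compound 1 `COc1ccc(S(=O)(=O)Oc2ccccc2/C=C(\C#N)C(=O)Nc2nnc(-c3cccs3)s2)cc1`: 67%
- compound 2 `N#C/C(=C\c1ccccc1OS(=O)(=O)c1ccc([N+](=O)[O-])cc1)C(=O)Nc1nnc(-c2cccs2)s1`: 23%
- compound 3 `COc1ccc(-c2nnc(NC(=O)/C(C#N)=C/c3cccc(OS(=O)(=O)c4ccc(C)cc4)c3)s2)cc1`: 73%

Compound 1 lies within the scatter of compound 3 and well beyond the scatter from compound 2, so it sits in the upper pair of the three numbers. Compound 4 `COc1ccc(Cc2nnc(NC(=O)/C(C#N)=C/c3ccccc3OS(=O)(=O)c3ccc(OC)cc3)s2)cc1` keeps the rest of compound 1 and carries 4-methoxybenzyl in place of thiophen-2-yl on an aromatic carbon. Within the data shown here, the one measured step, a number 44 percentage points lower from compound 1 to compound 2 (beyond the scatter), is large, but it concerns nitro in place of methoxy at another place and says nothing direct about this change. Compound 3 differs from compound 1 in several places, yet with a six-membered aromatic ring of carbon only at this place compound 3 gives 73%. In this assay no change beyond the scatter is therefore expected, with only a slight, uncertain downward lean. The expected step is a number 7 percentage points lower from compound 1 to compound 4 (within the scatter). The estimate for compound 4 is 60%, within an expected range of 36% to 80%.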

Compound 4, percent growth inhibition at one concentration: 100%
Beside the measured number, compound 4's estimate is 40 percentage points below it; measured number outside the range, above it.
By their numbers in this assay, from the lowest: compound 2; then compounds 1 and 3 (each within the scatter of the next); then compound 4.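

In this assay, 4-methoxybenzyl in place of thiophen-2-yl gives a number 33 percentage points higher from compound 1 to compound 4 (beyond the scatter). This shows that the position on the aromatic carbon, next to the ring nitrogen and next to the ring sulfur, can itself move growth inhibition beyond the scatter, and that the larger 4-methoxybenzyl is accepted there. No available evidence explains this step.

The compounds shown leave open whether the gain needs the methoxy group, as plain benzyl would test. They also leave open how a longer chain such as 2-phenylethyl, or an amine such as morpholine, would behave at this position.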